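Allyl and propargyl amide series: whole-animal toxicity notes

The source may hold more compounds than are shown below. What is called first, only, known or untested is meant among the compounds shown, and "the series" means these compounds.

Measured compounds in a toxicity assay on the whole organism (strain Icem-CET (SPF Caw)) for cytotoxicity, with Mus musculus as the target; a higher number here means that more compound is needed for the effect, a lower number that less compound is needed:
compound 1 `C=CCNC(=O)/C(C)=C(\C)c1ccc(Br)cc1` gives 500 mg/kg
compound 2 `C=CCNC(=O)/C(C)=C(\C)c1ccc(OC)cc1` gives 300 mg/kg
compound 3 `C#CCNC(=O)/C(C)=C(\C)c1ccc(C)cc1` gives 200 mg/kg

Compound 3 stands at the low end of the three numbers. Against compound 2 its gap is within the scatter, so no order between the two can be read; against compound 1 the gap is beyond the scatter, and compound 1 sits higher in this assay.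

Compound 4 `C=CCNC(=O)/C(C)=C(\C)c1ccc(C)cc1` is not yet measured. It differs from compound 3 by vinyl in place of ethynyl on a saturated chain carbon bound to an amide-type nitrogen; the aromatic part and the amide are kept, and the same difference read one bond further out is propargyl to allyl.

Within the data shown here, the only measured step, a 1.7-fold lower number from compound 1 to compound 2 (0.22 log units; within the scatter), concerns the aromatic substituent and does not touch the chain on the amide nitrogen. Among the measured compounds shown here, compounds 1 and 2 carry allyl and compound 3 carries propargyl, but the aromatic substituent differs as well in each pairing, so no measured step bears directly on the change from compound 3 to compound 4. With nothing to anchor a shift in either direction, no step beyond the scatter is expected in this assay, and the estimate for compound 4 is placed near compound 3 with a range wide enough to cover the scatter.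

For compound 4 the expected value in this assay is 250 mg/kg, with a range from 130 mg/kg to 500 mg/kg. The expected step of a 1.3-fold higher number from compound 3 to compound 4 (0.10 log units; within the scatter) is taken to lie within the scatter.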

Compound 4, dose for half-maximal effect: 170 mg/kg
Compound 4: the middle estimate sits 1.5-fold (0.17 log units) above what was measured, within the range that was stated.
By their numbers in this assay, from the lowest: compounds 4, 3, 2 and 1 (each within the scatter of the next, the first and the last beyond it).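

In this assay the chain on the amide nitrogen can now be read on its own: with the methyl-bearing aromatic part held fixed, vinyl in place of ethynyl on a saturated chain carbon bound to an amide-type nitrogen gives a 1.2-fold lower number from compound 3 to compound 4 (0.07 log units; within the scatter), so propargyl and allyl cannot be ordered in this pair. With allyl held fixed, the aromatic substituent can now be read at three members, and a 1.8-fold lower number from compound 2 to compound 4 (0.25 log units; within the scatter) leaves methoxy and methyl without an order. In contrast, a 2.9-fold lower number from compound 1 to compound 4 (0.47 log units; beyond the scatter) separates methyl from bromo, the only one of the three new steps to do so, and that separation is modest. Nothing at hand offers a reason for any of these steps.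

As far as these compounds go, the propargyl to allyl change has been read only with methyl on the aromatic carbon, so its size with bromo or methoxy there remains open. Also open, from the compounds shown here alone, is how this assay responds to a saturated propyl chain or a longer chain on the amide nitrogen, or to an amine or a carboxylic acid on the aromatic carbon.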